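From pyridin-2-yl to isopropyl on the chain

The source may hold more compounds than are shown below. What is called first, only, known or untested is meant among the compounds shown, and "the series" means these compounds.

In an in vivo ADME assay on the whole organism for pharmacokinetics, with Rattus norvegicus as the target (on this read-out higher numbers stand for wider distribution into tissues and lower numbers for narrower distribution), compound 1 `Cc1cc(C(=O)Nc2ccccc2)nn1Cc1cc(Cl)ccc1OCc1ccccc1` stands as "not determined" (no result reported). Compound 2 `Cc1cc(C(=O)NCc2ccccc2)nn1Cc1cc(Cl)ccc1OCc1ccccc1` gives 9.3 L/kg, and compound 3 `Cc1cc(NC(=O)OCc2ccccn2)nn1Cc1cc(Cl)ccc1OCc1ccccc1` gives 3 L/kg, the lower of the two numbers available. Compound 4 `Cc1cc(NC(=O)OCC(C)C)nn1Cc1cc(Cl)ccc1OCc1ccccc1` departs from compound 3 at one place: isopropyl in place of pyridin-2-yl on a saturated chain carbon bound to an oxygen next to a carbonyl group. Within the data shown here, the only measured step, a 3.1-fold lower number from compound 2 to compound 3 (0.49 log units; beyond the scatter), is an exchange on an aromatic carbon and bears on this change only loosely. A small rise, not clearly beyond the scatter, is therefore expected in this assay. The estimated step is a 1.3-fold higher number from compound 3 to compound 4 (0.12 log units; within the scatter). For compound 4 the expected value is 4 L/kg, with an estimated range of 1.7 L/kg to 9 L/kg.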

Compound 4, volume of distribution at steady state: 3.9 L/kg
Compound 4: middle estimate off by 1.0-fold (0.01 log units), on the high side; the measured number falls inside the stated range.
By their numbers in this assay, from the lowest: compounds 3 and 4 (each within the scatter of the next); then compound 2.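

In this assay, replacing the pyridin-2-yl on this chain carbon with isopropyl removes the ring and its hydrogen-bond acceptor, yet gives only a 1.3-fold higher number from compound 3 to compound 4 (0.11 log units; within the scatter). The lower number relative to the benzylcarbamoyl compound therefore does not depend on the pyridine ring: (isobutoxycarbonyl)amino in place of benzylcarbamoyl on an aromatic carbon still gives a 2.4-fold lower number from compound 2 to compound 4 (0.38 log units; beyond the scatter). No measurement in hand accounts for either step.

Still open, from the compounds shown here alone, is how the number responds at this chain carbon to an amine, a carboxylic acid or a longer chain. A phenyl ring here, with no hetero atom, also remains to be compared with pyridin-2-yl.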